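The source may hold more compounds than are shown below. What is called first, only, known or untested is meant among the compounds shown, and "the series" means these compounds.

Compound 1 `CN1CCN(c2nc(N)nc(CCCOc3ccc(Cl)c(Cl)c3)n2)CC1` gives 906 nM in an assay on CHO-K1 cells for displacement of a labelled ligand from 5-hydroxytryptamine receptor 6 (Homo sapiens), read by scintillation counting, with a stated time of 1 h; on this read-out lower numbers stand for stronger inhibition and higher numbers for weaker inhibition.
Compound 2 `CN1CCN(c2nc(N)nc(CCCOc3cc(Cl)ccc3Cl)n2)CC1` gives 1460 nM in this assay.

Of the two measured compounds, compound 2 carries the higher number, though the gap between the two is a 1.6-fold higher number from compound 1 to compound 2 (0.21 log units; within the scatter), which stays within the scatter. Compound 3 `CN1CCN(c2nc(N)nc(CCCOc3cccc(Cl)c3Cl)n2)CC1` has not yet been measured. It differs from compound 2 by 2,3-dichlorophenyl in place of 2,5-dichlorophenyl on an oxygen on a saturated carbon. For the measured compounds named here, the only measured step that bears on this kind of change is the one from compound 1 to compound 2, where moving the two chlorine atoms around the ring gave a 1.6-fold higher number from compound 1 to compound 2 (0.21 log units; within the scatter), a shift within the scatter. On that evidence, a further rearrangement of the same two chlorine atoms is expected to give no step beyond the scatter, with no clear direction. Compound 3 is therefore estimated at 1300 nM in this assay, between 450 nM and 3800 nM, an expected step of a 1.1-fold lower number from compound 2 to compound 3 (0.05 log units; within the scatter).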

Compound 3, inhibition constant: 649 nM
Compound 3: middle estimate off by 2.0-fold (0.30 log units), on the high side, and the stated range covers the measured number.
By their numbers in this assay, from the lowest: compounds 3, 1 and 2 (each within the scatter of the next, the first and the last beyond it).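

In this assay, the place on an oxygen on a saturated carbon now shows that moving the same two chlorine atoms around the ring can give a step beyond the scatter: 2,3-dichlorophenyl in place of 2,5-dichlorophenyl gives a 2.2-fold lower number from compound 2 to compound 3 (0.35 log units; beyond the scatter), though the step is modest. The same 2,3-dichlorophenyl in place of 3,4-dichlorophenyl gives a 1.4-fold lower number from compound 1 to compound 3 (0.14 log units; within the scatter), so compound 1 and compound 3 cannot be told apart, and only compound 2 and compound 3 separate. No measurement at hand accounts for this step.

As far as these compounds go, it stays open whether a phenyl carrying a single chlorine, or methoxy groups in place of the chlorine atoms, would keep numbers of this size. From the compounds shown here alone, the outcome of a longer chain in place of the saturated chain carrying the oxygen is also open.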